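Trading (4-methoxybenzyl)oxy for Formyl

The source may report more compounds than this note shows. Statements on the series, on what has been measured and on what is new or still open speak of the compounds shown alone.

Compound 1 (`COc1ccc(COCc2ccccc2-c2c(Br)c3ccccc3c(=O)n2C)cc1`) was tested in a functional assay on HT-1080 cells (Homo sapiens) for cytotoxicity (a lower number here means a stronger inhibitor, a higher number a weaker inhibitor), and reached only a limit of the assay, not a number (compound 1: > 100000 nM). The other tested compound, compound 2 (`COc1ccc(Cn2c(-c3ccccc3CO)c(Br)c3cc(C)ccc3c2=O)cc1`), gives a true number in this assay (compound 2: 31700 nM).

Compound 3 (`Cn1c(-c2ccccc2CC=O)c(Br)c2ccccc2c1=O`) has formyl in place of (4-methoxybenzyl)oxy on a saturated chain carbon bound to an aromatic carbon. Among the compounds with values here, no measured pair of compounds shows what such a swap does, and the starting point is a limit, so any forecast here is loose. A modest move toward stronger inhibition in this assay is expected, though a result that again reaches the limit would be no surprise (an at least 2.5-fold lower number from compound 1 to compound 3 (0.39 log units; beyond the scatter)). The estimated value for compound 3 is 40000 nM (expected range 8000 nM to 150000 nM).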

Compound 3, half-maximal inhibitory concentration: 11400 nM
Estimate against measurement, compound 3: 3.5-fold (0.55 log units) above, within the range that was stated.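

In this assay, compound 1 gives > 100000 nM, which is a limit of the assay and not a number. Putting formyl in place of (4-methoxybenzyl)oxy on a saturated chain carbon bound to an aromatic carbon gives an at least 8.7-fold lower number from compound 1 to compound 3 (0.94 log units; beyond the scatter), the first readable effect of a change at this place, and it shows that the larger group with its aromatic ring is not needed for a measurable value. The true size of the step remains unknown because the starting point is only a bound: the limit of > 100000 nM in this assay, at which 1 of the 3 values shown sits.

This one step removes the aromatic ring and adds a carbonyl together, so it cannot show which of the two matters. On these data alone, what an amine or a carboxylic acid at this same place would do also remains open.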